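Piperazine chain extension on the shared core: working notes

This account rests on a few compounds, and the source may have more. Where it says the series, first, only, none or still open, it means among the compounds named here.

compound 1 `O=C1c2c[n+]([O-])c3ccccc3c2C(=O)c2c1c1ccccc1n2CCN1CCCC1` gives 320 nM
compound 2 `O=C1c2c[n+]([O-])c3ccccc3c2C(=O)c2c1c1ccccc1n2CCN1CCCCC1` gives 620 nM

In a functional assay on MCF7 cells (Homo sapiens) for cytotoxicity, read by MTT assay, with a stated time of 72 h (on this read-out higher numbers stand for weaker inhibition and lower numbers for stronger inhibition), compound 2 at 620 nM is not separated from compound 1 on the two numbers available. Among the compounds with values here, the change to compound 3 `CN1CCN(CCCCCn2c3c(c4ccccc42)C(=O)c2c[n+]([O-])c4ccccc4c2C3=O)CC1` is 3-(4-methylpiperazin-1-yl)propyl in place of piperidin-1-yl on a saturated chain carbon, two bonds along the chain from an aromatic nitrogen and no measured compound tests it. Within the data shown here, the only measured step bearing on it is a 1.9-fold higher number from compound 1 to compound 2 (0.29 log units; within the scatter) at the same place, which gives no measured guide to a 3-(4-methylpiperazin-1-yl)propyl group. The estimated move is a 1.2-fold lower number from compound 2 to compound 3 (0.09 log units; within the scatter) and no firm direction is expected. In this assay compound 3 is expected at 500 nM with an estimated range of 150 nM to 1600 nM around it.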

Compound 3, half-maximal inhibitory concentration: 1260 nM
Compound 3: the middle estimate sits 2.5-fold (0.40 log units) below what was measured; the measured number falls inside the stated range.
By their numbers in this assay, from the lowest: compounds 1 and 2 (each within the scatter of the next); then compound 3.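

In this assay the change to 3-(4-methylpiperazin-1-yl)propyl on a saturated chain carbon gives a 2.0-fold higher number from compound 2 to compound 3 (0.31 log units; beyond the scatter) and, measured against pyrrolidin-1-yl at the same place, a 3.9-fold higher number from compound 1 to compound 3 (0.60 log units; beyond the scatter) as well. Unlike the change between compounds 1 and 2, which stays within the scatter, these steps show that this position can separate compounds, though only modestly. No evidence is available that bears on the reason for these steps.

Going by these compounds, the methylpiperazine ring and the longer chain enter together, so their shares in the steps remain open. A 2-(4-methylpiperazin-1-yl)ethyl group, or a pyrrolidine or piperidine on the longer chain, would pull the two apart.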